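Adding one methyl to the phenyl of compound 2

The compounds below may be only part of what the source reports. "The series", "measured", "known", "first", "only" and "open" are said of these compounds alone.

Compound 1 `COc1cc2c(Oc3ccc(NC(=O)c4nn(-c5ccccc5C)cc(C)c4=O)cc3)ccnc2cc1OCCCC(=O)NO` gives 4460 nM
Compound 2 `COc1cc2c(Oc3ccc(NC(=O)c4nn(-c5ccccc5)cc(C)c4=O)cc3)ccnc2cc1OCCCCCCC(=O)NO` gives 420 nM

In a functional assay on A549 cells (Homo sapiens) for inhibition, read by MTT assay, with a stated time of 72 h (a higher number here means a weaker inhibitor, a lower number a stronger inhibitor), compound 2 holds the lower of the two numbers, beyond the scatter from compound 1, which makes it the stronger inhibitor of the pair. Compound 3 `COc1cc2c(Oc3ccc(NC(=O)c4nn(-c5ccccc5C)cc(C)c4=O)cc3)ccnc2cc1OCCCCCCC(=O)NO` has not yet been measured. It differs from compound 2 by methyl in place of hydrogen on an aromatic carbon (methyl in place of hydrogen on an aromatic carbon, turning phenyl into 2-methylphenyl). Within the data shown here, no measured pair shows this change alone, so no step beyond the scatter is expected in this assay for it. The estimated 1.1-fold higher number from compound 2 to compound 3 (0.03 log units; within the scatter) therefore stays small. The expected value for compound 3 is 450 nM (estimated range 170 nM to 1200 nM).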

Compound 3, half-maximal inhibitory concentration: 3130 nM
Compound 3: middle estimate off by 7.0-fold (0.84 log units), on the low side; measured number outside the range, above it.
By their numbers in this assay, from the lowest: compound 2; then compounds 3 and 1 (each within the scatter of the next).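

In this assay, among these compounds, turning phenyl into 2-methylphenyl gives a 7.5-fold higher number from compound 2 to compound 3 (0.87 log units; beyond the scatter) and so provides the first reading of this change on its own, showing that this single methyl matters here. With 2-methylphenyl in place, the longer chain ending in hydroxycarbamoyl gives a 1.4-fold lower number from compound 1 to compound 3 (0.15 log units; within the scatter) and so does not separate the two compounds. No measurement at hand explains either result. From the compounds shown here alone, whether a fluorine or a methoxy group on that aromatic carbon would act like methyl remains open. So does whether chain length matters with plain phenyl.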